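This account rests on a few compounds, and the source may have more. Where it says the series, first, only, none or still open, it means among the compounds named here.

Working notes on a small set of compounds built around the core of compound 1 `O=C1OCC[C@@H]1NC(=S)SCCOc1cccc2ccccc12`. In a functional assay on PC-3 cells (Homo sapiens) for antiproliferative activity, read by MTT assay, with a stated time of 72 h (on this read-out higher numbers stand for weaker inhibition and lower numbers for stronger inhibition), compound 1 gives only the assay limit > 64000 nM, not a number. the limit of > 64000 nM in this assay, at which 1 of the 3 values shown sits, states that one of the three values shown sits at that limit. Compound 2 `COc1ccccc1/C=C/C(=O)c1ccc(OCC(=O)N[C@H]2CCOC2=O)cc1` gives 7240 nM in this assay, the lower of the two numbers shown. Compound 3 `O=C1OCC[C@@H]1NC(=S)SCCOc1ccccc1[N+](=O)[O-]` gives 24000 nM in this assay, a higher number than compound 2, the gap lying beyond the usual scatter. For the measured compounds named here, the three measured compounds differ from one another in several places at once, so no single step between measured compounds is available and no trend can be drawn from them.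

Compound 4 `O=C(COc1ccc(C(=O)/C=C/c2ccc(Br)cc2)cc1)N[C@H]1CCOC1=O` has not yet been measured. It differs from compound 2 in one place: 4-bromophenyl in place of 2-methoxyphenyl on a double-bonded chain carbon bound to a double-bonded chain carbon. Going by the values given here, no measured pair in this set varies just this part, so the size of the step is open. Expected is a step of a 1.2-fold lower number from compound 2 to compound 4 (0.08 log units; within the scatter), within or near the scatter, in no firm direction. For compound 4 the expected value in this assay is 6000 nM, with a range from 2000 nM to 20000 nM.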

Compound 4, half-maximal inhibitory concentration: > 64000 nM
Compound 4: no number, only a limit; the forecaster's own chance of this, stated with the estimate: 10%; at least 10-fold (1.02 log units) between middle value and limit.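

In this assay compound 4 gives only a limit, > 64000 nM, not a number. For the compounds shown here, this is the first change in the set made in one place alone, and 4-bromophenyl in place of 2-methoxyphenyl on a double-bonded chain carbon bound to a double-bonded chain carbon gives an at least 8.8-fold higher number from compound 2 to compound 4 (0.94 log units; beyond the scatter), so the group at this place clearly affects the read-out, which the earlier compounds, differing in several places at once, could not show. The full size of the step cannot be read, and compound 4 now shares the limit with compound 1, a compound from the other structural type in the set: the limit of > 64000 nM in this assay, at which 2 of the 4 values shown sit.

Going by these compounds, whether the loss of inhibition goes with the departure of the methoxy group, the arrival of the bromine, or the changed location of the substituent on the phenyl ring stays open, as this single swap alters all three together. On these data alone, a plain phenyl at this place would help separate these readings, and how a phenyl bearing a dimethylamino group would behave here is equally open.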